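The source may hold more compounds than are shown below. What is called first, only, known or untested is meant among the compounds shown, and "the series" means these compounds.

Compound 1, `Fc1ccccc1CSc1nnc(-c2cnccn2)o1`, was examined in a functional assay on BGC-823 cells (Homo sapiens) for antiproliferative activity, read by MTT assay, with a stated time of 48 h (a lower number here means a stronger inhibitor, a higher number a weaker inhibitor), and gave 18200 nM. Compound 2, `Fc1ccc(CSc2nnc(-c3cnccn3)o2)c(F)c1`, differs from it by fluoro in place of hydrogen on an aromatic carbon; in this assay compound 2 gives 33000 nM, the move being a 1.8-fold higher number from compound 1 to compound 2 (0.26 log units; within the scatter). Compound 3, `Fc1ccc(CSc2nnc(-c3cnccn3)s2)cc1`, is built on a different core; the difference between the two cores is not broken down here. In this assay compound 3 gives 29300 nM, which sits alongside the numbers of compound 1 and compound 2 without a separation beyond the scatter. The unmeasured compound 4, `Fc1ccc(CSc2nnc(-c3cnccn3)s2)c(F)c1`, differs from compound 3 by fluoro in place of hydrogen on an aromatic carbon. This is the same kind of change as that from compound 1 to compound 2, though not the same: here the entering fluoro stands ortho to a large group, whereas in compound 2 it stands para to a large group. The earlier step was a 1.8-fold higher number from compound 1 to compound 2 (0.26 log units; within the scatter), and a step of similar size is expected here, a 1.4-fold higher number from compound 3 to compound 4 (0.14 log units; within the scatter). Compound 4 is accordingly estimated at 40000 nM, with a likely range from 15000 nM to 110000 nM.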

Compound 4, half-maximal inhibitory concentration: 14500 nM
The estimate for compound 4 lay 2.8-fold (0.44 log units) above the measured number; measured number outside the range, below it.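

In this assay, the new step is a 2.0-fold lower number from compound 3 to compound 4 (0.31 log units; beyond the scatter), a modest one, and it does not match the earlier step on the other core: the same change on two cores in this assay, a 1.8-fold higher number (0.26 log units; within the scatter) from compound 1 to compound 2 and a 2.0-fold lower number (0.31 log units; beyond the scatter) from compound 3 to compound 4, 3.7-fold (0.56 log units) apart, beyond the scatter of two such steps. So, across these two pairs, the effect of adding a fluoro in place of hydrogen on an aromatic carbon cannot be carried from one core to the other in either size or direction. This is no clean test of the core alone, however: the entering fluoro stands ortho to a large group in compound 4 but at another place in compound 2, so core and place change together, and one pair on each core gives no rule for the series.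

The compounds shown leave open whether a chloro, methoxy or trifluoromethyl group at these places would follow the fluoro steps on each core. They also leave open whether an amine or a carboxylic acid on the six-membered aromatic ring of carbon only would give steps that agree between the two cores.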